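The compounds below may be only part of what the source reports. "The series", "measured", "known", "first", "only" and "open" are said of these compounds alone.

In a functional assay on PC-3 cells (Homo sapiens) for inhibition, read by WST assay, tested at 10 uM (on this read-out higher numbers stand for a stronger effect at the one concentration tested and lower numbers for a weaker effect), three close relatives of the same amide have already been tested. Compound 1 `O=C(CCCNC(=O)c1cc(C(F)(F)F)cc(C(F)(F)F)c1)Nc1ccc(Cl)cc1` gives 0%. Compound 2 `O=C(Nc1ccc(Cl)cc1)C1CCCN(C(=O)c2cc(C(F)(F)F)cc(C(F)(F)F)c2)C1` gives 0%. Compound 3 `O=C(NCCCNc1ccc(Cl)cc1)c1cc(C(F)(F)F)cc(C(F)(F)F)c1` gives 0%, which leaves compound 3 level with both compound 1 and compound 2 at the digits shown, with none of the three standing apart from the others.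

Compound 4 `O=C(NCCCOc1ccc(Cl)cc1)c1cc(C(F)(F)F)cc(C(F)(F)F)c1` differs from compound 3 in one place: 4-chlorophenoxy in place of (4-chlorophenyl)amino on a saturated chain carbon, three bonds along the chain from an amide-type nitrogen. Among the measured compounds shown here, the only measured step that touches this part of the molecule is no change at the digits printed from compound 1 to compound 3 (within the scatter), which swapped the group at the same place without moving the read-out beyond the scatter. For the measured compounds named here, nothing measured so far points to an effect from what sits at that end of the chain, so the step from compound 3 to compound 4 is expected to be no change at the digits printed from compound 3 to compound 4 (within the scatter), that is, no change beyond the scatter. Compound 4 is therefore estimated to give 0% in this assay, within a range from 0% to 10%.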

Compound 4, a percentage reported as inhibition, at one concentration (the size of the read-out at that concentration, not a potency): 0%
Beside the measured number, compound 4's estimate shows no gap at the digits printed, within the range that was stated.
By their numbers in this assay, from the lowest: compounds 1, 2, 3 and 4 (each within the scatter of the next).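

In this assay, the step from the nitrogen link to an oxygen link shows no change at the digits printed from compound 3 to compound 4 (within the scatter), so losing the hydrogen-bond donor counted on the (4-chlorophenyl)amino group leaves the read-out where it was. The larger swap, 4-chlorophenoxy in place of (4-chlorophenyl)carbamoyl at the same place on the chain, likewise shows no change at the digits printed from compound 1 to compound 4 (within the scatter), which means that three different end groups at this place now stand level. Nothing available offers an explanation for this flat result.

With none of these compounds showing any inhibition in this assay, the series has no active member against which a change at this place could register, so the role of this position remains unknown. As far as these compounds go, whether a carboxylic acid, a piperazine or a longer chain here would produce any inhibition stays open.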